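The source may report more compounds than this note shows. Statements on the series, on what has been measured and on what is new or still open speak of the compounds shown alone.

Compounds with results in hand:
compound 1 `O=C(CN1CN(c2ccccc2)C2(CCN(C(=O)c3ccc(C4CCCCC4)cc3)CC2)C1=O)NCCCCO` gives 10300 nM;
compound 2 `CC(C)(C)c1ccc(C(=O)N2CCC3(CC2)C(=O)N(CC(=O)NCCCCO)CN3c2ccccc2)cc1` gives 19200 nM;
compound 3 `CCc1nn(CC)c(C2CCN(C(=O)CN3CN(c4ccccc4)C4(CCN(C(=O)c5ccc(C6CCCCC6)cc5)CC4)C3=O)CC2)c1C` gives "not determined" (no result reported), that is, no result reported.

Both numbers come from an assay on HEK293 cells for displacement of a labelled ligand from NPC1-like intracellular cholesterol transporter 1 (Homo sapiens); a lower number here means a stronger inhibitor, a higher number a weaker inhibitor. Within the data shown here, compound 1 holds the lower of the two values, but its nearest neighbour, compound 2, is within the scatter of it: the only single-change step known, a 1.9-fold higher number from compound 1 to compound 2 (0.27 log units; within the scatter), replaces cyclohexyl with tert-butyl on an aromatic carbon and does not move the number beyond the scatter.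

Compound 4 `CS(=O)(=O)N1CCN(C(=O)CN2CN(c3ccccc3)C3(CCN(C(=O)c4ccc(C5CCCCC5)cc4)CC3)C2=O)CC1` leaves the shared core of compound 1 untouched and alters the amide end instead: 4-(methylsulfonyl)piperazin-1-yl in place of (4-hydroxybutyl)amino on a carbonyl carbon. No measured step bears on this part of the molecule; the one step shown concerns the aromatic substituent, not the carbonyl carbon, so it offers no guidance on direction. With nothing in hand pointing either way, the expected step of a 1.2-fold higher number from compound 1 to compound 4 (0.07 log units; within the scatter) is taken as none beyond the scatter, carrying a wide uncertainty. Compound 4 is therefore estimated at 12000 nM in this assay, within a range from 3500 nM to 40000 nM.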

Compound 4, half-maximal inhibitory concentration: 6300 nM
Estimate against measurement, compound 4: 1.9-fold (0.28 log units) above; measured number inside the range.
By their numbers in this assay, from the lowest: compounds 4, 1 and 2 (each within the scatter of the next, the first and the last beyond it).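

In this assay, replacing (4-hydroxybutyl)amino with 4-(methylsulfonyl)piperazin-1-yl on the carbonyl carbon gives a 1.6-fold lower number from compound 1 to compound 4 (0.21 log units; within the scatter) and so does not move the number beyond the scatter. Among these compounds, this is the first measured step at this position, and it shows that a group with a six-membered non-aromatic ring and 0 hydrogen-bond donors can take the place of an open chain with 2 hydrogen-bond donors while the number stays within the scatter of compound 1. No measurement shown here accounts for this result.

The compounds shown leave open whether a plain piperazine without the methylsulfonyl group, a carboxylic acid or a longer chain on this carbonyl carbon would give a step beyond the scatter. They also leave open whether tert-butyl in place of cyclohexyl would give a similar step with the amide end of compound 4.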